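Shifting the hydroxyl on the pendant phenyl of compound 2

A few compounds are considered here, and "the series" means these few. Any claim that something is new, unique, unknown or untested is made for them only; others in the source may bear on it.

Measured compounds and values:
- compound 1, `Oc1ccc(-c2cc(-c3cccnc3)nc(-c3ccccc3Cl)c2)cc1`: "not determined" (no result reported)
- compound 2, `Oc1ccc(-c2cc(-c3cccs3)nc(-c3ccccc3Cl)c2)cc1`: 4190 nM
- compound 3, `Oc1ccc(-c2cc(-c3ccc(Cl)cc3)nc(-c3cccs3)c2)cc1`: 7660 nM

Compound 1 `Oc1ccc(-c2cc(-c3cccnc3)nc(-c3ccccc3Cl)c2)cc1` carries a pyridin-3-yl group in the position where compounds 2 and 3 carry a thiophen-2-yl or a chlorophenyl, and it has no result in a functional assay on DU-145 cells (Homo sapiens) for cytotoxicity, read by CCK-8 assay and cell counting, with a stated time of 2 days; on this read-out higher numbers stand for weaker inhibition and lower numbers for stronger inhibition. Compound 2 `Oc1ccc(-c2cc(-c3cccs3)nc(-c3ccccc3Cl)c2)cc1` gives 4190 nM in this assay, the lowest of the two numbers on hand. Among the measured compounds shown here, compound 3 `Oc1ccc(-c2cc(-c3ccc(Cl)cc3)nc(-c3cccs3)c2)cc1` gives 7660 nM; the only measured step, a 1.8-fold higher number from compound 2 to compound 3 (0.26 log units; within the scatter), is within the scatter, so these two compounds cannot be ordered.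

Compound 4 `Oc1cccc(-c2cc(-c3cccs3)nc(-c3ccccc3Cl)c2)c1` differs from compound 2 by 3-hydroxyphenyl in place of 4-hydroxyphenyl on an aromatic carbon. For the measured compounds named here, no measured step touches the hydroxyphenyl group, so nothing on hand bears directly on this change; the one step that exists shows that exchanging a substituent on the core left the number within the scatter. On that basis, compound 4 is expected to stay close to compound 2, with the estimated step of a 1.3-fold higher number from compound 2 to compound 4 (0.12 log units; within the scatter) lying within the scatter. Compound 4 is therefore estimated at 5500 nM in this assay, with a range from 2000 nM to 16000 nM.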

Compound 4, half-maximal inhibitory concentration: 1700 nM
For compound 4 the middle estimate is 3.2-fold (0.51 log units) above the measured one; measured number below the stated range.
By their numbers in this assay, from the lowest: compound 4; then compounds 2 and 3 (each within the scatter of the next).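

Among the compounds shown here, exchanging 4-hydroxyphenyl for 3-hydroxyphenyl leaves the atoms of the group unchanged and gives a 2.5-fold lower number from compound 2 to compound 4 (0.39 log units; beyond the scatter) in this assay as the first step in this set that lies beyond the scatter, though only a modest one. Compounds 1, 2 and 3 all carry 4-hydroxyphenyl and could not show that this position, opposite the ring nitrogen of the shared core, responds to where the hydroxyl sits on the pendant ring. No measurement on hand accounts for the lower number with 3-hydroxyphenyl.

The compounds shown leave open whether the hydroxyl is needed at all, and what 2-hydroxyphenyl, or a methoxy group, an amine or a carboxylic acid in the hydroxyl's stead, would do at this position. They also leave open whether the same exchange would give a lower number with the other substituents on the core, such as those of compound 1 and compound 3.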